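The source may report more compounds than this note shows. Statements on the series, on what has been measured and on what is new or still open speak of the compounds shown alone.

Measured so far: compound 1 `CCOC(=O)c1c(-c2ccc(OC)cc2)oc2ccc(OCCCCCCN3C(=O)C(=O)c4ccccc43)cc12` with 256 ug/mL; compound 2 `CCO/N=C1\C(=O)N(CCCOc2ccc3oc(-c4ccc(OC)cc4)c(C(=O)OCC)c3c2)c2ccccc21` with 16 ug/mL; compound 3 `CCO/N=C1\C(=O)N(CCCOc2ccc3oc(-c4ccc(OC)cc4)c(C(=O)OCC)c3c2)c2ccc(OC)cc21` with 32 ug/mL.

In an ADME assay on Vero cells (Chlorocebus sabaeus) for cytotoxicity, read by MTT assay, with a stated time of 72 h (a lower number here means that less compound is tolerated, a higher number that more compound is tolerated), compound 1 gives the highest of the three numbers; compound 3 sits closest to it and compound 2 furthest, both gaps beyond the scatter. For the measured compounds named here, the only step between measured compounds that differ in one place is a 2.0-fold higher number from compound 2 to compound 3 (0.30 log units; within the scatter), methoxy in place of hydrogen on an aromatic carbon, which lies within the scatter and does not touch the part of the molecule that changes here.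

Compound 4 `CCOC(=O)c1c(-c2ccc(OC)cc2)oc2ccc(OCCCCCN3C(=O)/C(=N\O)c4ccccc43)cc12` differs from compound 1 by a group of 12 heavy atoms (8 carbon, 2 nitrogen, 2 oxygen; one five-membered non-aromatic ring with 1 hetero atom, one six-membered aromatic ring of carbon only) in place of a group of 12 heavy atoms (9 carbon, 1 nitrogen, 2 oxygen; one five-membered non-aromatic ring with 1 hetero atom, one six-membered aromatic ring of carbon only), on a saturated chain carbon, five bonds along the chain from an oxygen on an aromatic ring. Going by the values given here, no measured step bears directly on this change. Compounds 2 and 3, which carry a related oxime-bearing group on a shorter chain but differ from compound 1 in more than one place, both give lower numbers than compound 1, so a drop is expected rather than a rise. For compound 4 the estimate in this assay is 64 ug/mL, with a range from 16 ug/mL to 256 ug/mL, a step of a 4.0-fold lower number from compound 1 to compound 4 (0.60 log units; beyond the scatter) that is expected to fall beyond the scatter.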

Compound 4, half-maximal cytotoxic concentration: 64 ug/mL
Compound 4: middle estimate and measured number agree at the digits printed; the measured number falls inside the stated range.
By their numbers in this assay, from the lowest: compounds 2, 3 and 4 (each within the scatter of the next, the first and the last beyond it); then compound 1.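

In this assay, for the compounds shown here, the step of a 4.0-fold lower number from compound 1 to compound 4 (0.60 log units; beyond the scatter) is the first one at this saturated chain carbon, and it lies beyond the scatter, whereas the only earlier step, a 2.0-fold higher number from compound 2 to compound 3 (0.30 log units; within the scatter), lay within it and did not touch this part of the molecule. The two groups have the same ring types and 12 heavy atoms each, yet the entering group has 8 carbon and 2 nitrogen atoms in place of 9 carbon and 1 nitrogen, with 1 hydrogen-bond donor and 3 acceptors in place of 0 donors and 2 acceptors, so a change of this limited size is enough to shift the number at this position. Nothing measured here explains the shift.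

This single step does not separate the hydrogen-bond donor from the rest of the change. Going by these compounds, how a longer chain carrying the entering group, or an amine or a carboxylic acid at this position, would read in this assay remains open.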